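Oxolanyloxy for methoxy on the quinazoline cinnamamide series

This account rests on a few compounds, and the source may have more. Where it says the series, first, only, none or still open, it means among the compounds named here.

In a functional assay on PC-3 cells (Homo sapiens) for cytotoxicity, read by MTT assay, with a stated time of 72 h (a lower number here means a stronger inhibitor, a higher number a weaker inhibitor), compound 1 `COc1cc2ncnc(Nc3ccc(F)c(Cl)c3)c2cc1NC(=O)/C=C/c1ccc(F)cc1Cl` gives 32700 nM, the highest of the two numbers reported; compound 3 `COc1cc2ncnc(Nc3ccc(F)c(Cl)c3)c2cc1NC(=O)/C=C/c1ccccc1[N+](=O)[O-]` gives 14300 nM, and compound 2 `COc1ccc(/C=C/C(=O)Nc2cc3c(Nc4ccc(F)c(Cl)c4)ncnc3cc2OC)cc1` is reported as "not active" (no number reported) without a number. For the measured compounds named here, the one measured step, a 2.3-fold lower number from compound 1 to compound 3 (0.36 log units; beyond the scatter), concerns the aryl group on the unsaturated chain, not the alkoxy group on the core. Compound 4 `O=C(/C=C/c1ccc(F)cc1Cl)Nc1cc2c(Nc3ccc(F)c(Cl)c3)ncnc2cc1O[C@H]1CCOC1` differs from compound 1 by oxolan-3-yl in place of methyl on an oxygen on an aromatic ring. Going by the values given here, no measured pair bears on this change, so the expected step of a 1.1-fold lower number from compound 1 to compound 4 (0.04 log units; within the scatter) is none beyond the scatter, with a wide range given that compound 2 returned no number. Compound 4 is estimated at 30000 nM, expected between 10000 nM and 90000 nM.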

Compound 4, half-maximal inhibitory concentration: 7150 nM
Estimate against measurement, compound 4: 4.2-fold (0.62 log units) above; the measured number lies below the stated range.
By their numbers in this assay, from the lowest: compounds 4 and 3 (each within the scatter of the next); then compound 1.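

In this assay, the group on the oxygen on an aromatic ring also moves the read-out, not only the aryl group on the chain: oxolan-3-yl in place of methyl gives a 4.6-fold lower number from compound 1 to compound 4 (0.66 log units; beyond the scatter). The larger group, with its five-membered ring, added hydrogen-bond acceptor and defined stereocentre, is therefore accepted at this position without loss in this cell read-out. No measurement here explains the step.

On these data alone, it remains open whether the opposite stereocentre, or a dimethylaminoethyl group on the same oxygen, would give a comparable number. Also open, as far as these compounds go, is whether the step carries over to the 2-nitrophenyl compound 3.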